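This account rests on a few compounds, and the source may have more. Where it says the series, first, only, none or still open, it means among the compounds named here.

Compound 1 `Cc1cc(N)ccc1-c1nc2ccccc2s1`: in a functional assay on MCF7 cells (Homo sapiens) for inhibition (a higher number here means a weaker inhibitor, a lower number a stronger inhibitor), compound 1 gives < 0.1 nM; < 0.1 nM (2 entries).
Compound 2 `Nc1ccc(-c2nc3ccccc3s2)c(Br)c1`: compound 2 gives < 0.1 nM, which is a limit of the assay, not a number.
Compound 3 `Nc1ccc(-c2nc3ccccc3s2)c(I)c1`: compound 3 gives < 0.1 nM, also a limit.

Compound 3 therefore stands only at the floor of what this assay can report, with no single number of its own. The change to compound 4 `Nc1ccc(-c2nc3ccccc3s2)c(Cl)c1` is chloro in place of iodo on an aromatic carbon. Going by the values given here, the one measured step that resembles it, a step that the two limits leave unreadable from compound 2 to compound 3, cannot be read as a size, since both ends sit at the limit of < 0.1 nM in this assay, at which 2 of the 3 values shown sit. No step beyond the scatter is expected here in either direction. Compound 4 is estimated at 0.05 nM, within 0.01 nM to 0.3 nM, an expected step that the limit leaves unreadable from compound 3 to compound 4.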

Compound 4, half-maximal inhibitory concentration: < 0.1 nM
Compound 4: no number, only a limit; the forecaster's own chance of this, stated with the estimate: 70%; the middle value does not contradict the limit.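

No step to compound 4 can be read from compound 2 or compound 3, because all three sit at the same limit: the limit of < 0.1 nM in this assay, at which 3 of the 4 values shown sit.

The compounds shown leave open whether bromo, iodo and chloro differ at all in this assay, as compound 2, compound 3 and compound 4 each lack a single number.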